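Phenyl for Benzoyl on a Ceramidase Inhibitor Core

This account rests on a few compounds, and the source may have more. Where it says the series, first, only, none or still open, it means among the compounds named here.

Of the compounds shown here, three built on one shared core have been measured in an assay on HEK293 cells for inhibition of acid ceramidase (Homo sapiens), with a stated time of 10 min; a higher number here means a weaker inhibitor, a lower number a stronger inhibitor. Compound 1 `O=C(c1ccccc1)c1ccc2c(c1)oc(=O)n2C(=O)NCCCCc1ccccc1` carries a benzoyl group on the core and gives 29 nM. Compound 2 `O=C(NCCCCc1ccc2ccccc2c1)n1c(=O)oc2ccccc21`, which bears no substituent on the core and ends its chain in a naphthyl group, gives 71 nM in this assay. Compound 3 `O=C(NCCCCc1ccccc1)n1c(=O)oc2ccc([N+](=O)[O-])cc21`, with a nitro group on the core, gives 3 nM. Among these three, compound 1 stands second highest: compound 2 sits at a higher number, beyond the scatter, and compound 3 at a much lower number, also beyond the scatter.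

Compound 4 `O=C(NCCCCc1ccccc1)n1c(=O)oc2cc(-c3ccccc3)ccc21` has not yet been measured. It differs from compound 1 in one place: phenyl in place of benzoyl on an aromatic carbon. Among the compounds with values here, no measured pair shows this change directly, so the expectation rests on the spread of the three numbers. Compound 3, at 3 nM, is the strongest of the three, and compound 2, at 71 nM, the weakest; compound 1 with its benzoyl lies between them. The step of a 1.7-fold higher number from compound 1 to compound 4 (0.24 log units; within the scatter) is expected to be modest, toward a higher number, and may fall within the scatter. For compound 4 the half-maximal inhibitory concentration is estimated at 50 nM, with a range from 15 nM to 160 nM.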

Compound 4, half-maximal inhibitory concentration: 84 nM
Beside the measured number, compound 4's estimate is 1.7-fold (0.23 log units) below it; low and high end bracket the measured number.
By their numbers in this assay, from the lowest: compound 3; then compound 1; then compounds 2 and 4 (each within the scatter of the next).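

In this assay, within the data shown here, putting phenyl in place of benzoyl on this aromatic carbon brings a 2.9-fold higher number from compound 1 to compound 4 (0.46 log units; beyond the scatter), the first step that changes one place only. It shows that this position is not indifferent to the change, as the step lies beyond the scatter, even though a six-membered aromatic ring of carbon stays on the same carbon and only the carbonyl of benzoyl, with its hydrogen-bond acceptor, is gone. No measurement at hand accounts for the rise in the number, so this single pair gives its size and direction but not its origin.

The compounds shown leave open whether the carbonyl itself matters or any atom joining the outer ring to the core would serve as well, and a benzyl or a phenoxy group on this same carbon would show whether such a compound lies closer to compound 1 or to compound 4. They also leave open how a plain hydrogen, or a smaller group such as methoxy or chlorine, would compare with benzoyl and phenyl at this position.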